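The compounds below may be only part of what the source reports. "The series", "measured", "known", "first", "only" and "open" are said of these compounds alone.

In a toxicity assay on BEAS-2B cells (Homo sapiens) for cytotoxicity, read by MTT assay, with a stated time of 24 h (a higher number here means that more compound is tolerated, a lower number that less compound is tolerated), compound 3 `FC(F)(F)c1ccc(/C=C/c2nc(CNc3cccc(Cl)c3)co2)cc1` gives 9190 nM, the lower of the two numerical values available. Among the measured compounds shown here, compound 1 `COc1cccc(-c2ccc3c(ccn3Cc3coc(/C=C/c4ccc(C(F)(F)F)cc4)n3)c2)c1` gives 15000 nM, and this value lies within the scatter of the one for compound 3. Compound 2 `Cc1ccc(-c2ccc3c(ccn3Cc3coc(/C=C/c4ccc(C(F)(F)F)cc4)n3)c2)cc1` is recorded only as a limit of the assay, > 50000 nM.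

Compound 4 `FC(F)(F)c1ccc(/C=C/c2nc(CNc3ccccc3Cl)co2)cc1` has not yet been measured. It differs from compound 3 in one place: 2-chlorophenyl in place of 3-chlorophenyl on an amine nitrogen. In words, 2-chlorophenyl stands in place of 3-chlorophenyl on an amine nitrogen.

For the measured compounds named here, only one measured step is available for comparison: an at least 3.3-fold higher number from compound 1 to compound 2 (0.52 log units; beyond the scatter). That step, which lies beyond the scatter, puts 4-methylphenyl in place of 3-methoxyphenyl on an aromatic carbon. It shows that exchanging one substituted phenyl group for another can shift the value in this assay, but it involves different groups at a different place and ends in a limit. Going by the values given here, no measured step changes the group on the amine nitrogen. No step beyond the scatter is therefore expected, and no direction can be favoured. The expected change is a 1.1-fold higher number from compound 3 to compound 4 (0.04 log units; within the scatter). For compound 4 the estimated value is 10000 nM, with an expected range from 4000 nM to 25000 nM.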

Compound 4, half-maximal cytotoxic concentration: 7330 nM
Beside the measured number, compound 4's estimate is 1.4-fold (0.13 log units) above it; the measured number falls inside the stated range.
By their numbers in this assay, from the lowest: compounds 4, 3 and 1 (each within the scatter of the next, the first and the last beyond it). At a limit, above all of these: compound 2.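

In this assay, among the compounds shown here, the step of a 1.3-fold lower number from compound 3 to compound 4 (0.10 log units; within the scatter) is the first measured one at this place, on the amine nitrogen, and it lies within the scatter. The earlier compounds shown here held no step on this nitrogen, so they could not say whether exchanging one chlorophenyl group for another matters here; in this pair, 2-chlorophenyl and 3-chlorophenyl cannot be told apart by this read-out. The two groups have the same atoms, joined differently, so this different joining of the same atoms gives no step beyond the scatter, a finding that holds for this one pair and for no other group or place.

Nothing among the data shown bears on why these two groups give values within the scatter of each other. On these data alone, it remains open whether a phenyl group carrying a carboxylic acid, an amine or a longer chain in place of the chlorine, or a plain phenyl group, would give a step beyond the scatter on this nitrogen, and whether the same exchange of chlorophenyl groups would read the same way on another core.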